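Piperidin-1-yl in place of acetyl: cytotoxicity outlook

The source may hold more compounds than are shown below. What is called first, only, known or untested is meant among the compounds shown, and "the series" means these compounds.

Compound 1 `CC(=O)c1ccc(NCc2cncn2Cc2ccc(-c3ccccc3)cc2)cc1-c1ccccc1` is the reference for this step. In a toxicity assay on NIH3T3 cells (Mus musculus) for cytotoxicity, read by resazurin assay (a higher number here means that more compound is needed for the effect, a lower number that less compound is needed), compound 1 gives > 10000 nM, which is a limit of the assay rather than a number. Compound 2 `COC(=O)c1ccc(NCc2cncn2Cc2ccccc2)cc1-c1ccccc1` sits at > 1000 nM, again a limit. Compound 3 `COC(=O)c1ccc(NCc2cncn2Cc2cccc([N+](=O)[O-])c2)cc1-c1ccccc1` stands at > 10000 nM, also a limit. Going by the values given here, the only step between measured compounds, a step that the two limits leave unreadable from compound 2 to compound 3, is not readable; both of its ends are limits. Among the compounds with values here, compound 1 therefore stands with the values at the limit of > 10000 nM in this assay, at which 2 of the 3 values shown sit, while the remaining value sits at the limit of > 1000 nM in this assay, at which 1 of the 3 values shown sits, and no measured step gives a readable size or direction.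

Compound 4 `c1ccc(-c2ccc(Cn3cncc3CNc3ccc(N4CCCCC4)c(-c4ccccc4)c3)cc2)cc1` is the unmeasured member. It differs from compound 1 by piperidin-1-yl in place of acetyl on an aromatic carbon. Within the data shown here, no measured step touches this group, and the single recorded step offers nothing on size or direction. The expectation rests on the three limits alone: compound 4 is expected at 15000 nM with a range from 3000 nM to 60000 nM, and most likely the assay again reports only a limit. The step that the limit leaves unreadable from compound 1 to compound 4 is expected to stay within the scatter, with no change in cytotoxicity beyond it.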

Compound 4, half-maximal effective concentration: > 1000 nM
Compound 4 ended at the assay's limit; the forecaster's own chance of this, stated with the estimate: 70%; the middle value does not contradict the limit.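

In this assay compound 4 gives > 1000 nM, a limit of the assay. Compound 1 gives > 10000 nM, also a limit, so the step between compound 1 and compound 4 cannot be read in size or direction. The compounds shown leave open whether piperidin-1-yl in place of acetyl changes cytotoxicity at all.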